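The source may report more compounds than this note shows. Statements on the series, on what has been measured and on what is new or still open speak of the compounds shown alone.

Measured in a functional assay for inhibition, with Homo sapiens as the target; on this read-out lower numbers stand for tighter binding and higher numbers for weaker binding:
- compound 1 `COc1ccc(OC(C)(C)C2OCC(C/C=C\CCC(=O)O)C(c3cccnc3)O2)cc1`: 302 nM
- compound 2 `CSc1ccccc1OC(C)(C)C1OCC(C/C=C\CCC(=O)O)C(c2cccnc2)O1`: 89.1 nM
- compound 3 `CC(C)(Oc1ccccc1O)C1OCC(C/C=C\CCC(=O)O)C(c2cccnc2)O1`: 95.5 nM

In this assay, compound 3 gives 95.5 nM. It cannot be told apart from its nearest neighbour, as a 1.1-fold higher number from compound 2 to compound 3 (0.03 log units; within the scatter) shows, while compound 1 stands clearly apart, with a 3.2-fold lower number from compound 1 to compound 3 (0.50 log units; beyond the scatter).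

Compound 4 `CC(C)(Cc1ccc(F)cc1)C1OCC(C/C=C\CCC(=O)O)C(c2cccnc2)O1` carries 4-fluorobenzyl in place of 2-hydroxyphenoxy on a saturated chain carbon bound to two saturated chain carbons and a saturated ring carbon.

Among the compounds with values here, no measured step makes this exact change, since all three compounds keep the oxygen. The nearest guides are the modest 3.4-fold lower number from compound 1 to compound 2 (0.53 log units; beyond the scatter) and a 3.2-fold lower number from compound 1 to compound 3 (0.50 log units; beyond the scatter), which exchange the aromatic group. Within the data shown here, compound 1, the only measured compound with a 4-substituted ring, has the highest number, and compound 4 also bears a 4-substituted ring. A modest rise in this assay is therefore expected, though with wide uncertainty. The expected change is a 2.3-fold higher number from compound 3 to compound 4 (0.36 log units; beyond the scatter). For compound 4 the estimate is 220 nM, with an expected range of 70 nM to 700 nM.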

Compound 4, dissociation constant: 89.1 nM
For compound 4 the middle estimate is 2.5-fold (0.39 log units) above the measured one, and the stated range covers the measured number.
By their numbers in this assay, from the lowest: compounds 2, 4 and 3 (each within the scatter of the next); then compound 1.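

At the saturated chain carbon bound to two saturated chain carbons and a saturated ring carbon, 4-fluorobenzyl, which has no oxygen, stands in for the phenoxy groups in this assay with results within the scatter: the exchange gives a 1.1-fold lower number from compound 3 to compound 4 (0.03 log units; within the scatter) and no change at the digits printed from compound 2 to compound 4 (within the scatter) in the two closest comparisons. The high number of compound 1 therefore does not extend to every group with a 4-substituted ring, as a 3.4-fold lower number from compound 1 to compound 4 (0.53 log units; beyond the scatter) makes clear for 4-fluorobenzyl against 4-methoxyphenoxy. Nothing on hand gives a reason for this result.

The exchange alters the atom linking the ring and the substituent on the ring together, so the two effects cannot be separated here. On these data alone, whether a plain benzyl, a 4-methoxybenzyl or a 4-fluorophenoxy group would fall with compound 4 or with compound 1 stays open.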